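The source may report more compounds than this note shows. Statements on the series, on what has been measured and on what is new or still open speak of the compounds shown alone.

Three compounds of the series carry numbers in a functional assay on HeLa cells (Homo sapiens) for antiproliferative activity, with a stated time of 5 days; on this read-out lower numbers stand for stronger inhibition and higher numbers for weaker inhibition. Compound 1 `COc1ccc(-n2nc(-c3ccc4ccccc4c3)nc2N2C(=O)COC23C=CC(=O)C=C3)cc1` gives 200 nM; compound 2 `O=C1C=CC2(C=C1)OCC(=O)N2c1nc(-c2ccc3ccccc3c2)nn1-c1ccccc1` gives 120 nM; compound 3 `Cc1ccc(-n2nc(-c3ccc4ccccc4c3)nc2N2C(=O)COC23C=CC(=O)C=C3)cc1` gives 150 nM. The steps among them, a 1.7-fold lower number from compound 1 to compound 2 (0.22 log units; within the scatter), a 1.3-fold lower number from compound 1 to compound 3 (0.12 log units; within the scatter) and a 1.3-fold higher number from compound 2 to compound 3 (0.10 log units; within the scatter), all stay within the scatter, so compound 3 sits in a flat set: its value lies close to those of compound 2 and compound 1, with neither gap beyond the scatter.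

Compound 4 `O=C1C=CC2(C=C1)OCC(=O)N2c1nc(-c2ccc3ccccc3c2)nn1-c1ccc(C(F)(F)F)cc1` differs from compound 3 by trifluoromethyl in place of methyl on an aromatic carbon. For the measured compounds named here, no measured step exchanges a methyl for a trifluoromethyl. Going by the values given here, the steps that bear on this place are the three above, which exchange hydrogen, methyl and methoxy on the same aromatic carbon, and none of them moves the number in this assay beyond the scatter. On that basis the expected step is a 1.2-fold higher number from compound 3 to compound 4 (0.08 log units; within the scatter), that is, no change beyond the scatter, in this assay. Compound 4 is estimated at 180 nM, with a range from 70 nM to 450 nM.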

Compound 4, half-maximal inhibitory concentration: 390 nM
Compound 4: middle estimate off by 2.2-fold (0.34 log units), on the low side; the range from low to high includes it.
By their numbers in this assay, from the lowest: compounds 2, 3, 1 and 4 (each within the scatter of the next, the first and the last beyond it).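

In this assay, for the compounds shown here, this position is no longer flat: with trifluoromethyl on the aromatic carbon there is a 2.6-fold higher number from compound 3 to compound 4 (0.41 log units; beyond the scatter) and a 3.3-fold higher number from compound 2 to compound 4 (0.51 log units; beyond the scatter), the only steps in the set beyond the scatter, both modest. The exception is methoxy, with a 2.0-fold higher number from compound 1 to compound 4 (0.29 log units; within the scatter) staying within the scatter, so trifluoromethyl separates from hydrogen and methyl but not from methoxy, and the position tolerates all four groups without a large loss. No measurement available here accounts for the step.

On these data alone, how an amine, a carboxylic acid or a longer chain on this aromatic carbon would read in this assay stays open. As far as these compounds go, with one example of the change, it also stays open whether trifluoromethyl in place of methyl gives a step of this size on any other core.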